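This account rests on a few compounds, and the source may have more. Where it says the series, first, only, none or still open, it means among the compounds named here.

Going by the values given here, in an ADME assay on RAW264.7 cells (Mus musculus) for cytotoxicity, read by MTT assay, with a stated time of 48 h (on this read-out lower numbers stand for higher toxicity in this test and higher numbers for lower toxicity in this test), three related compounds have numbers so far. Compound 1 (`C#CCN(c1nc(-c2cccc([N+](=O)[O-])c2)no1)C1CCCCC1`) gives 34.2 ug/mL, compound 2 (`CC(=O)OC[C@H]1O[C@H](OC[C@@H](Cn2cc(CN(c3nc(-c4cccc(C)c4)no3)C3CCCCC3)nn2)OC(C)=O)C=C[C@@H]1OC(C)=O`) gives 46.4 ug/mL and compound 3 (`C#CCOc1ccc(-c2noc(NC3CCCCC3)n2)cc1`) gives 38.3 ug/mL. Compound 1 therefore sits within the usual scatter of both others, and the three numbers cannot be ranked.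

Compound 4 (`C#CCN(c1nc(-c2cccc(C)c2)no1)C1CCCCC1`) has not yet been measured. It has methyl in place of nitro on an aromatic carbon of compound 1: methyl in place of nitro on an aromatic carbon. Among the compounds with values here, no pair of measured compounds isolates this change, so the data give no direct measure of it. Compound 2 carries the same methyl, yet at 46.4 ug/mL compound 2 remains within the scatter of compound 1. No step beyond the scatter is therefore expected in this assay, in either direction. The estimated change is a 1.2-fold higher number from compound 1 to compound 4 (0.07 log units; within the scatter), which would lie within the scatter. For compound 4, the expected half-maximal cytotoxic concentration is 40 ug/mL, with an estimated range from 22 ug/mL to 70 ug/mL.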

Compound 4, half-maximal cytotoxic concentration: 25.9 ug/mL
For compound 4 the middle estimate is 1.5-fold (0.19 log units) above the measured one; measured number inside the range.
By their numbers in this assay, from the lowest: compounds 4, 1, 3 and 2 (each within the scatter of the next).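

The exchange of nitro for methyl on an aromatic carbon, meta to a large group, can now be read directly: in this assay the step is a 1.3-fold lower number from compound 1 to compound 4 (0.12 log units; within the scatter) and lies within the scatter. On the core of compound 1, this assay therefore does not separate the two groups, even though methyl has fewer heavy atoms than nitro and no hydrogen-bond acceptors. No supporting data bear on this result, so it stands as an observation alone.

The compounds shown leave open whether an amine, a carboxylic acid or a chlorine atom at this place would also stay within the scatter of compound 1. They also leave open whether the same exchange would read alike on another core, since compound 2 and compound 3 each differ from compound 1 in more than one place.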